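Benzoyl for benzyl at the sugar-side oxygen: cytotoxicity

The source may report more compounds than this note shows. Statements on the series, on what has been measured and on what is new or still open speak of the compounds shown alone.

Three compounds of the series carry a value in an ADME assay on A549 cells (Homo sapiens) for cytotoxicity; a higher number here means a weaker inhibitor, a lower number a stronger inhibitor. Compound 1 `O=C(OC[C@H]1O[C@@H](OC[C@H](O)[C@@H](O)c2ccc(O)cc2)[C@H](O)[C@@H](O)[C@@H]1O)c1ccccc1` gives > 10000 nM, a limit of the assay rather than a number. Compound 2 `O=C(OC[C@H]1O[C@@H](O[C@@H](C(=O)O)c2ccccc2)[C@H](O)[C@@H](O)[C@@H]1O)c1ccccc1` gives > 10000 nM, again only a limit. Compound 3 `O=C(OC[C@H]1O[C@@H](OC[C@H]2O[C@@H](OCc3ccccc3)[C@H](O)[C@@H](O)[C@@H]2O)[C@H](O)[C@@H](O)[C@@H]1O)c1ccccc1` gives > 10000 nM, also a limit. Compound 3 therefore stands where the whole set sits, at the limit of > 10000 nM in this assay, at which 3 of the 3 values shown sit. Compound 4 `O=C(OC[C@H]1O[C@@H](OC[C@H]2O[C@@H](OC(=O)c3ccccc3)[C@H](O)[C@@H](O)[C@@H]2O)[C@H](O)[C@@H](O)[C@@H]1O)c1ccccc1` is not yet measured; it differs from compound 3 by benzoyl in place of benzyl on an oxygen on a saturated carbon. With every value of the set at the limit, no step beyond the scatter is expected, and the step from compound 3 to compound 4 is estimated as a step that the limit leaves unreadable from compound 3 to compound 4. Compound 4 is expected to give about 15000 nM in this assay, within 8000 nM to 40000 nM, most probably again only a limit.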

Compound 4, half-maximal inhibitory concentration: > 10000 nM
Compound 4: no number, only a limit; the forecaster's own chance of this, stated with the estimate: 85%; the middle value lies beyond the limit too.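

Compound 3 and compound 4 both give only a limit in this assay, so no step between them can be read: the limit of > 10000 nM in this assay, at which 4 of the 4 values shown sit.

The compounds shown leave open whether benzoyl and benzyl differ at all at this place, and what number any of the four compounds would give.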